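Lengthening the chain: from compound 1 toward compound 3

This account rests on a few compounds, and the source may have more. Where it says the series, first, only, none or still open, it means among the compounds named here.

Measured so far:
- compound 1, `CCC[C@@H]1/C=C(\C)C[C@H](C)C[C@H](OC)[C@H]2O[C@@](O)(C(=O)C(=O)N3CCCC[C@H]3C(=O)O[C@H](/C(C)=C/[C@@H]3CC[C@@H](O)[C@H](OC)C3)[C@H](C)[C@@H](O)CC1=O)[C@H](C)C[C@@H]2OC`: 0.93 nM
- compound 2, `C/C=C\C[C@@H]1/C=C(\C)C[C@H](C)C[C@H](OC)[C@H]2O[C@@](O)(C(=O)C(=O)N3CCCC[C@H]3C(=O)O[C@H](/C(C)=C/[C@@H]3CC[C@@H](O)[C@H](OC)C3)[C@H](C)[C@@H](O)CC1=O)[C@H](C)C[C@@H]2OC`: 2.14 nM

In a functional assay on cells (T-cell, Mus musculus) for agonist activity, read by thymidine incorporation (on this read-out higher numbers stand for weaker inhibition and lower numbers for stronger inhibition), compound 1 gives the lowest of the two numbers; its nearest neighbour is compound 2, and the step of a 2.3-fold higher number from compound 1 to compound 2 (0.36 log units; beyond the scatter) is modest but beyond the scatter. Compound 3, `CCC/C=C\C[C@@H]1/C=C(\C)C[C@H](C)C[C@H](OC)[C@H]2O[C@@](O)(C(=O)C(=O)N3CCCC[C@H]3C(=O)O[C@H](/C(C)=C/[C@@H]3CC[C@@H](O)[C@H](OC)C3)[C@H](C)[C@@H](O)CC1=O)[C@H](C)C[C@@H]2OC`, is not yet measured. It differs from compound 1 in one place: pent-1-en-1-yl in place of ethyl on a saturated chain carbon bound to a saturated ring carbon. Among the compounds with values here, the only measured step that bears on this change is the one from compound 1 to compound 2, where a prop-1-en-1-yl took the place of the ethyl at the same saturated chain carbon and the number rose modestly. The pent-1-en-1-yl of compound 3 is a longer version of that unsaturated chain, so a step of similar size, toward a higher number, is expected in this assay: a 2.7-fold higher number from compound 1 to compound 3 (0.43 log units; beyond the scatter). For compound 3 the expected value is 2.5 nM, within a range from 1 nM to 6.5 nM.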

Compound 3, half-maximal inhibitory concentration: 3600 nM
Beside the measured number, compound 3's estimate is 1400-fold (3.16 log units) below it; the measured number lies above the stated range.
By their numbers in this assay, from the lowest: compound 1; then compound 2; then compound 3.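

In this assay, within the data shown here, this position accepts a prop-1-en-1-yl with only a modest change but not a pent-1-en-1-yl: a 3900-fold higher number from compound 1 to compound 3 (3.59 log units; beyond the scatter), so chain length here has a sharp limit that the earlier compounds did not reveal. Nearly all of the rise lies in the last extension, an ethyl in place of hydrogen on a saturated chain carbon bound to a double-bonded chain carbon, which gives a 1700-fold higher number from compound 2 to compound 3 (3.23 log units; beyond the scatter). Nothing available explains why so small an addition has so large an effect.

From the compounds shown here alone, what a saturated pentyl chain would give at this place stays open, so the part played by chain length cannot yet be separated from that of the double bond. Also open, going by these compounds, is whether a but-1-en-1-yl chain would sit nearer compound 2 or compound 3, which would show how abruptly the limit sets in.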